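The source may hold more compounds than are shown below. What is called first, only, known or untested is meant among the compounds shown, and "the series" means these compounds.

The measured compounds:

- Compound 1, `CC(=O)c1ccc(OCC(O)CN2CCCCC2)cc1`: in a functional assay on CCRF-CEM/VCR-1000 cells (Homo sapiens) for inhibition (a lower number here means a stronger inhibitor, a higher number a weaker inhibitor), compound 1 gives 75900 nM.
- Compound 2, `O=C(CCc1ccccc1)c1ccc(OCC(O)CN2CCCCC2)cc1`: in this assay compound 2 gives 1360 nM.
- Compound 3, `CC(=O)c1cccc(OCC(O)CN2CCCCC2)c1`: in this assay compound 3 gives 9070 nM.

Compound 1 and compound 2 share one core and differ in a single place: benzyl in place of hydrogen on a saturated chain carbon bound to a carbonyl carbon. That one change made the step of a 56-fold lower number from compound 1 to compound 2 (1.75 log units; beyond the scatter). Compound 3 is built from the same atoms as compound 1, joined differently; the difference between the two cores is not broken down here.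

Compound 4, `O=C(CCc1ccccc1)c1cccc(OCC(O)CN2CCCCC2)c1`, has not yet been measured. It stands to compound 3 as compound 2 stands to compound 1: benzyl in place of hydrogen on a saturated chain carbon bound to a carbonyl carbon. The place is described in the same words in both pairs, so this is the same change, carried out on the core of compound 3 instead of the core of compound 1. If the change works on the core of compound 3 as it did on the core of compound 1, compound 4 is expected to give a clearly lower number than compound 3. Going by the values given here, because the only evidence is the single step of a 56-fold lower number from compound 1 to compound 2 (1.75 log units; beyond the scatter), the expected step is set somewhat smaller than that one, allowing for a change that may not carry over fully from one core to the other. The step from compound 3 to compound 4 in this assay is expected to be a 36-fold lower number from compound 3 to compound 4 (1.56 log units; beyond the scatter). For compound 4 the estimate in this assay is 250 nM, with a likely range from 60 nM to 1500 nM.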

Compound 4, half-maximal inhibitory concentration: 390 nM
Compound 4: middle estimate off by 1.6-fold (0.19 log units), on the low side, and the stated range covers the measured number.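

In this assay the core of compound 3 responds strongly to the same change, with a 23-fold lower number from compound 3 to compound 4 (1.37 log units; beyond the scatter), so benzyl in place of hydrogen on a saturated chain carbon bound to a carbonyl carbon lowers the number on both cores. Set side by side, the two steps cannot be told apart: the same change on two cores in this assay, a 56-fold lower number (1.75 log units; beyond the scatter) from compound 1 to compound 2 and a 23-fold lower number (1.37 log units; beyond the scatter) from compound 3 to compound 4, 2.4-fold (0.38 log units) apart, within the scatter of two such steps The change therefore carried over from the core of compound 1 to the core of compound 3 with no difference in size beyond the scatter, but this rests on only two pairs in a single assay, and it shows neither why the change works nor that it would hold on any other core.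

The compounds shown cover only the step from methyl to phenethyl, so it remains open how the number would respond to a shorter chain such as ethyl or to a longer chain such as phenylbutyl. Going by these compounds, it also remains open whether the chain needs its phenyl ring at all, or whether a chain ending in an amine, a carboxylic acid or a cyclohexyl ring would give a step of similar size.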